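Adding a third methoxy group to a chalcone-pyrazole growth inhibitor

The source may report more compounds than this note shows. Statements on the series, on what has been measured and on what is new or still open speak of the compounds shown alone.

Compound 1 `COc1cc(-c2cc(/C=C/C(=O)c3ccc(N)cc3)[nH]n2)cc(OC)c1OC`: 320 nM
Compound 2 `COc1ccc(C(=O)/C=C/c2cc(-c3cc(OC)c(OC)c(OC)c3)n[nH]2)cc1OC`: 270 nM

Both values come from a functional assay on SR cells (Homo sapiens) for inhibition, read by sulforhodamine B assay, with a stated time of 48 h; a lower number here means a stronger inhibitor of growth, a higher number a weaker inhibitor of growth. Compound 2 sits alongside compound 1: a 1.2-fold lower number from compound 1 to compound 2 (0.07 log units; within the scatter). Compound 3 `COc1cc(C(=O)/C=C/c2cc(-c3cc(OC)c(OC)c(OC)c3)n[nH]2)cc(OC)c1OC` differs from compound 2 by methoxy in place of hydrogen on an aromatic carbon. Going by the values given here, the only measured step swapped the whole aromatic ring on the carbonyl carbon, and it stayed within the scatter, so it bears only loosely on this smaller change. Among the compounds with values here, no step adds a methoxy group here. Compound 3 is therefore expected to show a 1.0-fold higher number from compound 2 to compound 3 (0.02 log units; within the scatter), nothing beyond the scatter. Compound 3 is estimated at 280 nM, between 120 nM and 650 nM.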

Compound 3, concentration for 50% growth inhibition: 390 nM
For compound 3 the middle estimate is 1.4-fold (0.14 log units) below the measured one; low and high end bracket the measured number.
By their numbers in this assay, from the lowest: compounds 2, 1 and 3 (each within the scatter of the next).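

Adding a methoxy group on an aromatic carbon, ortho to a methoxy group, gives a 1.4-fold higher number from compound 2 to compound 3 (0.16 log units; within the scatter) in this assay. So this position accepts the extra group with no step beyond the scatter, and the ring on the carbonyl carbon can carry this third methoxy group while compound 3 stays in the same range as compound 2. Nothing available bears on the reason for this result.
From the compounds shown here alone, whether a hydroxyl group or a fluorine atom at this position would give a step beyond the scatter remains open.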